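The source may report more compounds than this note shows. Statements on the series, on what has been measured and on what is new or still open speak of the compounds shown alone.

Measured in a functional assay on DU-145 cells (Homo sapiens) for cytotoxicity, read by trypan blue exclusion, with a stated time of 96 h; a lower number here means a stronger inhibitor, a higher number a weaker inhibitor:
- Compound 1 `COc1cc(OC)c(/C=C/S(=O)(=O)Cc2ccc(OC)c(N)c2)c(OC)c1`: 4 nM
- Compound 2 `COc1ccc(CS(=O)(=O)/C=C/c2c(OC)cc(O)cc2OC)cc1N`: 200 nM
- Compound 3 `COc1cc(OC)c(/C=C/S(=O)(=O)Cc2ccc(Cl)cc2N)c(OC)c1`: 2500 nM

Compound 1 has the lowest number of the three, which makes it the strongest inhibitor in this small set. Compound 4 `COC(=O)C(Nc1cc(CS(=O)(=O)/C=C/c2c(OC)cc(OC)cc2OC)ccc1OC)c1ccccc1` keeps the core of compound 1 and differs at one place, on a nitrogen on an aromatic ring: methoxycarbonyl)(benzyl in place of hydrogen on a nitrogen on an aromatic ring. In words, methoxycarbonyl)(benzyl stands in place of hydrogen there.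

Within the data shown here, no measured step changes that nitrogen by adding a group to it, so the evidence is indirect. The closest is the swap of the ring carrying the amino group, a 630-fold higher number from compound 1 to compound 3 (2.80 log units; beyond the scatter). Changing a methyl on an oxygen elsewhere gave a 50-fold higher number from compound 1 to compound 2 (1.70 log units; beyond the scatter). Both changes from compound 1 raised the number by a large amount, so a higher number is also expected here, though with wide uncertainty. The expected change is a 15-fold higher number from compound 1 to compound 4 (1.18 log units; beyond the scatter). For compound 4 the estimated value is 60 nM, with an expected range of 8 nM to 450 nM.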

Compound 4, half-maximal inhibitory concentration: 75 nM
For compound 4 the middle estimate is 1.3-fold (0.10 log units) below the measured one, and the stated range covers the measured number.
By their numbers in this assay, from the lowest: compound 1; then compound 4; then compound 2; then compound 3.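

Among these compounds, this is the first direct look at the nitrogen on the aromatic ring, since the earlier steps changed a methyl on an oxygen or the whole amino-bearing ring. In this assay, placing methoxycarbonyl)(benzyl, with its 11 heavy atoms, in place of hydrogen on that nitrogen gives a 19-fold higher number from compound 1 to compound 4 (1.27 log units; beyond the scatter), so the change carries a clear cost. Even so, a group of this size is compatible with activity, as compound 4 still gives 75 nM, and no available evidence accounts for the size of the step.

On these data alone, it remains open which part of the group drives the step, the benzene ring or the methoxycarbonyl. A single methyl on that nitrogen, or a carboxylic acid in place of the methoxycarbonyl, would help to separate these contributions.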